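This account rests on a few compounds, and the source may have more. Where it says the series, first, only, none or still open, it means among the compounds named here.

Measured compounds in an ADME assay on A549 cells (Homo sapiens) for cytotoxicity, read by CCK-8 assay, with a stated time of 48 h; a lower number here means that less compound is tolerated, a higher number that more compound is tolerated:
- compound 1, `O=C(CNc1nc(N2CCCC2)nc2ccccc12)Nc1ccc2ccccc2c1`: 4770 nM
- compound 2, `CCN(CC)c1nc(NCC(=O)NCc2ccccc2)c2ccccc2n1`: > 100000 nM, which is a limit of the assay and not a number
- compound 3, `O=C(CNc1nc(N2CCc3ccccc3C2)nc2ccccc12)Nc1ccccc1`: 10700 nM

Of the two numbers given, compound 1 has the lowest; the nearest is compound 3, a step up of a size beyond the usual scatter. Compound 2 sits at the limit described in the limit of > 100000 nM in this assay, at which 1 of the 3 values shown sits, so it is not placed relative to the other two.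

The next compound to be read is compound 4, `O=C(CNc1nc(N2CCCC2)nc2ccccc12)Nc1cc(Cl)cc(Cl)c1`. Against compound 1 the change is 3,5-dichlorophenyl in place of naphthalen-2-yl on an amide-type nitrogen. The shared core of compound 1 and compound 4 is kept, and the change is confined to the aryl group on the amide-type nitrogen.

No step between two measured compounds isolates this kind of change, so the expectation rests on the spread of the numbers shown. In this assay the step from compound 1 to compound 4 is expected to be a 1.3-fold higher number from compound 1 to compound 4 (0.10 log units; within the scatter), that is, a shift of about the size seen between compound 1 and compound 3 or smaller, in either direction, with no firm ground for a larger move. Compound 4 is accordingly estimated at 6000 nM, with a range from 2000 nM to 20000 nM.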

Compound 4, half-maximal cytotoxic concentration: 5920 nM
Beside the measured number, compound 4's estimate is 1.0-fold (0.01 log units) above it, and the stated range covers the measured number.
By their numbers in this assay, from the lowest: compounds 1, 4 and 3 (each within the scatter of the next, the first and the last beyond it). At a limit, above all of these: compound 2.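

Within this assay, the exchange of naphthalen-2-yl for 3,5-dichlorophenyl on the amide-type nitrogen gives a 1.2-fold higher number from compound 1 to compound 4 (0.09 log units; within the scatter), the first step in this set confined to one place, which the earlier compounds could not provide. At this position, two six-membered aromatic rings of carbon only give way to one, two chlorine atoms enter, and the two numbers cannot be told apart, so these two aryl groups are interchangeable as far as this read-out can show. Nothing measured here bears on the reason for this result.

Open, as far as these compounds go, is whether this tolerance extends to groups of a different kind on the same nitrogen, such as a phenyl ring carrying a carboxylic acid or an amine, or a saturated cyclohexyl group or longer alkyl chain in place of the aryl group. Also open, from the compounds shown here alone, is whether the same exchange would read alike with the rest of the core of compound 1 altered, as a single change in one place at a time would be needed to show this.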